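Changing the Amide Aryl Group from Compound 3 to Compound 4

The source may report more compounds than this note shows. Statements on the series, on what has been measured and on what is new or still open speak of the compounds shown alone.

Three analogues share one core and differ only in the aryl group joined to the amide carbonyl. In a functional assay on MDA-MB-231 cells (Homo sapiens) for antiproliferative activity, read by CCK-8 assay, with a stated time of 72 h (on this read-out higher numbers stand for weaker inhibition and lower numbers for stronger inhibition), compound 1 `Cc1ccc(C(=O)Nc2cccc(-c3oc4cc(-c5ccc(F)cc5)ccc4c(=O)c3O)c2)cc1` gives 4350 nM, compound 2 `COc1ccccc1C(=O)Nc1cccc(-c2oc3cc(-c4ccc(F)cc4)ccc3c(=O)c2O)c1` gives 5110 nM, and compound 3 `COc1ccc(C(=O)Nc2cccc(-c3oc4cc(-c5ccc(F)cc5)ccc4c(=O)c3O)c2)c(F)c1` gives 17600 nM, the highest of the three numbers. The steps of a 4.0-fold higher number from compound 1 to compound 3 (0.61 log units; beyond the scatter) and a 3.4-fold higher number from compound 2 to compound 3 (0.54 log units; beyond the scatter) both show a modest rise when the 2-fluoro-4-methoxyphenyl group enters, while a 1.2-fold higher number from compound 1 to compound 2 (0.07 log units; within the scatter) stays within the scatter. Compound 4 `Cc1cc(C)cc(C(=O)Nc2cccc(-c3oc4cc(-c5ccc(F)cc5)ccc4c(=O)c3O)c2)c1` carries the change (3,5-dimethylphenyl in place of 2-fluoro-4-methoxyphenyl on a carbonyl carbon), an aryl group that, like compound 1, bears only methyl groups. Compound 1 gives 4350 nM with such a group, so a return toward that number is expected. The expected step of a 3.5-fold lower number from compound 3 to compound 4 (0.55 log units; beyond the scatter) is a modest fall in this assay. Compound 4 is therefore estimated at 5000 nM, within a range from 2500 nM to 12000 nM.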

Compound 4, half-maximal inhibitory concentration: 11900 nM
For compound 4 the middle estimate is 2.4-fold (0.38 log units) below the measured one; the range from low to high includes it.
By their numbers in this assay, from the lowest: compounds 1 and 2 (each within the scatter of the next); then compounds 4 and 3 (each within the scatter of the next).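

The step of a 1.5-fold lower number from compound 3 to compound 4 (0.17 log units; within the scatter) means that swapping 2-fluoro-4-methoxyphenyl for 3,5-dimethylphenyl on this carbonyl carbon gives no readable change. An aryl group bearing only methyl groups therefore does not guarantee the lower numbers, as a 2.7-fold higher number from compound 1 to compound 4 (0.44 log units; beyond the scatter) and a 2.3-fold higher number from compound 2 to compound 4 (0.37 log units; beyond the scatter) are both modest rises. No measurement shown here explains these differences between aryl groups.

All four groups are substituted phenyl rings. Going by these compounds, how a pyridine ring or a cyclohexyl group on this carbonyl carbon would compare remains open.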